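The source may hold more compounds than are shown below. What is called first, only, known or untested is meant among the compounds shown, and "the series" means these compounds.

Measured compounds:

Compound 2, `O=C(C1CC1)[C@H]1C[C@H]2CNC[C@H]2C1` — in an assay on CHO cells for displacement of a labelled ligand from Neuronal acetylcholine receptor; alpha3/beta4 (Homo sapiens), read by scintillation counting, with a stated time of 2 h (a higher number here means a weaker inhibitor, a lower number a stronger inhibitor), compound 2 gives 70 nM.
Compound 1, `CCC(=O)N1CC2CNCC2C1` — in this assay compound 1 gives 2100 nM.

Of the two numbers shown, compound 2 has the lower one. Compound 1 gives a higher number, and the gap between the two values is wide enough to lie beyond the usual scatter of repeated measurements. Among the measured compounds shown here, no step between the two has been worked out, since they differ in more than one place, so the two values are simply taken as they stand.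

Compound 3, `COC(=O)[C@H]1C[C@H]2CNC[C@H]2C1`, has not yet been measured in this assay. It keeps the shared core of compound 2 and differs from it in a single place: methoxy in place of cyclopropyl on a carbonyl carbon. The cyclopropyl leaves the carbonyl carbon, whose other neighbour is a saturated ring carbon, and a methoxy enters there.

For the measured compounds named here, no measured pair shows what such a change does here. The expectation for compound 3 is a modest rise in the number, a step from compound 2 to compound 3 of about a 2.9-fold higher number from compound 2 to compound 3 (0.46 log units; beyond the scatter), since compound 2 gives 70 nM and nothing in the data argues for a fall. Compound 3 is therefore estimated at 200 nM, in a range from 60 nM to 700 nM.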

Compound 3, inhibition constant: 400 nM
Estimate against measurement, compound 3: 2.0-fold (0.30 log units) below; the range from low to high includes it.
By their numbers in this assay, from the lowest: compound 2; then compound 3; then compound 1.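

In this assay, among the compounds shown here, the exchange of cyclopropyl for methoxy on a carbonyl carbon brings a 5.7-fold higher number from compound 2 to compound 3 (0.76 log units; beyond the scatter) and so gives the first reading of a single change. The earlier pair differed in more than one place and could say nothing about any one position, whereas this step shows that the group held on this carbonyl carbon matters to the number, even though the effect is modest. It also shows that the shared core with a methoxy in this place still gives a measurable value in this assay, so the cyclopropyl is not essential for a reading. Nothing among the data available bears on why the number rises.

Methoxy differs from cyclopropyl in more than one way, bringing an oxygen and losing the ring, and this single step cannot tell which of these differences goes with the rise. Going by these compounds, an ethyl group, with neither ring nor oxygen, or an amine on the same carbonyl carbon would be needed to pull those two differences apart, and the direction of the number for either group remains open.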